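This account rests on a few compounds, and the source may have more. Where it says the series, first, only, none or still open, it means among the compounds named here.

Measured in an ADME assay on L02 cells (Homo sapiens) for cytotoxicity, read by MTT assay, with a stated time of 24 h; on this read-out higher numbers stand for weaker inhibition and lower numbers for stronger inhibition:
- Compound 1 `CN1C/C(=C\c2ccncc2)C(=O)/C(=C/c2ccccc2F)C1`: 14900 nM
- Compound 2 `CN1C/C(=C\c2ccncc2)C(=O)/C(=C/c2ccccc2C(F)(F)F)C1`: 15800 nM
- Compound 3 `O=C1/C(=C/c2cccnc2)CN(S(=O)(=O)c2ccccc2)C/C1=C\c1ccccc1F`: 15300 nM

Compound 2, at 15800 nM, stands within the scatter of both other compounds, so the three values form a tight group. The next compound, compound 4 `O=C1/C(=C/c2ccncc2)CN(S(=O)(=O)c2ccc(F)cc2)C/C1=C\c1ccccc1C(F)(F)F`, has (4-fluorophenyl)sulfonyl in place of methyl on an amine nitrogen in a ring.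

For the measured compounds named here, the only measured step is a 1.1-fold higher number from compound 1 to compound 2 (0.03 log units; within the scatter). It concerns trifluoromethyl in place of fluoro on an aromatic carbon, so it does not test the change at the nitrogen. Going by the values given here, it shows only that this one change left the number within the scatter. Compound 3, at 15300 nM, also carries a sulfonyl group on that nitrogen, but it differs from compound 2 in other places too, which makes it only a loose guide.

On this evidence, no shift beyond the scatter is expected. The expected change is a 1.1-fold lower number from compound 2 to compound 4 (0.02 log units; within the scatter). In this assay, the estimate for compound 4 is 15000 nM, with an expected range of 7500 nM to 30000 nM.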

Compound 4, half-maximal inhibitory concentration: 12900 nM
The estimate for compound 4 lay 1.2-fold (0.07 log units) above the measured number; the measured number falls inside the stated range.
By their numbers in this assay, from the lowest: compounds 4, 1, 3 and 2 (each within the scatter of the next).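

In this assay, for the compounds shown here, compound 2 and compound 4 give the first direct reading at the amine nitrogen in the ring (a 1.2-fold lower number from compound 2 to compound 4 (0.09 log units; within the scatter)). Going by these compounds alone, earlier, the only step concerned an aromatic carbon, whereas here a single methyl gives way to (4-fluorophenyl)sulfonyl, which brings a six-membered aromatic ring and two hydrogen-bond acceptors, yet the number stays within the scatter. Nothing measured here offers an explanation for this outcome.

On these data alone, whether a group attached to that nitrogen through a carbonyl, such as acetyl, or a longer chain such as butyl would also stay within the scatter remains open. Equally open, as far as these compounds go, is what an amine or a carboxylic acid on the entering aromatic ring would do, and whether this one pair holds for other groups on the shared core.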